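The compounds below may be only part of what the source reports. "The series", "measured", "known", "first", "only" and "open" are said of these compounds alone.

Working notes on the series. In a functional assay on LoVo cells (Homo sapiens) for inhibition, read by colorimetric assay and MTT assay, with a stated time of 72 h (a higher number here means a weaker inhibitor, a lower number a stronger inhibitor), compound 1 (`Cn1c2cnc1OCCCCCCCCOc1cc(F)ccc1-2`) gives 32000 nM and compound 2 (`C=CCCCCOc1ccccc1-c1cnc(OCCCC=C)n1C`) gives 4000 nM as the lower of the two numbers, a gap beyond the scatter. Compound 3 (`C=CCCCCCOc1ncc(-c2ccccc2OCCCCC=C)n1C`) differs from compound 2 by one change: but-3-en-1-yl in place of vinyl on a saturated chain carbon, three bonds along the chain from an oxygen on an aromatic ring on a saturated chain carbon, three bonds along the chain from an oxygen on an aromatic ring. Among the compounds with values here, no measured pair shows a change of this kind. The expected step of a 1.3-fold lower number from compound 2 to compound 3 (0.12 log units; within the scatter) is small and is not expected to go beyond the scatter. In this assay compound 3 is estimated at 3000 nM with a range from 1000 nM to 9000 nM as the expected bounds.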

Compound 3, half-maximal inhibitory concentration: 32000 nM
Compound 3: middle estimate off by 11-fold (1.03 log units), on the low side; measured number outside the range, above it.
By their numbers in this assay, from the lowest: compound 2; then compounds 1 and 3 (each within the scatter of the next).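

In this assay, but-3-en-1-yl in place of vinyl on a saturated chain carbon, three bonds along the chain from an oxygen on an aromatic ring, gives an 8.0-fold higher number from compound 2 to compound 3 (0.90 log units; beyond the scatter) and so moves the number beyond the scatter. The position therefore responds to a change that adds only carbon and keeps the double bond outside aromatic rings. Nothing available explains this step.

From the compounds shown here alone, whether the intermediate allyl group would give a number nearer compound 2 or compound 3 remains open. Also open, going by these compounds, is how a saturated hexyl chain or a terminal amine would behave at this position.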